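The source may report more compounds than this note shows. Statements on the series, on what has been measured and on what is new or still open speak of the compounds shown alone.

Three compounds share one core and differ only in the group on an aromatic nitrogen. Compound 1 `Cn1c(=O)c2nn(C3CC4CCC3C4)nc2n(C)c1=O` gives 31000 nM in an assay on cell membranes from brain for displacement of a labelled ligand from adenosine receptor A1 (Bos taurus); on this read-out higher numbers stand for weaker inhibition and lower numbers for stronger inhibition. Compound 2 `CCCn1c(=O)c2nn(C3CCCC3)nc2n(CCC)c1=O` gives 1300 nM, and compound 3 `CCCn1c(=O)c2nn(C3CCCCC3)nc2n(CCC)c1=O` gives 1600 nM. Compound 3 therefore stands second highest of the three numbers, close to compound 2 and far from compound 1; the step of a 1.2-fold higher number from compound 2 to compound 3 (0.09 log units; within the scatter) stays within the scatter. Compound 4 `CCCn1c(=O)c2nn(C3CCCCC3O)nc2n(CCC)c1=O` is compound 3 with hydroxy in place of hydrogen on a saturated ring carbon. Among the compounds with values here, no measured step touches this ring other than the change of its size, and that step, a 1.2-fold higher number from compound 2 to compound 3 (0.09 log units; within the scatter), was small, so no step beyond the scatter is expected in this assay. The step expected is a 1.6-fold higher number from compound 3 to compound 4 (0.19 log units; within the scatter). Compound 4 is estimated at 2500 nM, with a range from 800 nM to 8000 nM.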

Compound 4, inhibition constant: 1400 nM
The estimate for compound 4 lay 1.8-fold (0.25 log units) above the measured number; the measured number falls inside the stated range.
By their numbers in this assay, from the lowest: compounds 2, 4 and 3 (each within the scatter of the next); then compound 1.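

In this assay hydroxy on a saturated ring carbon, next to the ring atom that bears a large group, gives a 1.1-fold lower number from compound 3 to compound 4 (0.06 log units; within the scatter) and so shows that this ring carbon can carry a hydroxy group with no step beyond the scatter. Set against cyclopentyl, 2-hydroxycyclohexyl gives a 1.1-fold higher number from compound 2 to compound 4 (0.03 log units; within the scatter) and likewise stays within the scatter. No evidence at hand bears on this result. From the compounds shown here alone, what an amine or a carboxylic acid on this ring carbon would give in this assay stays open, as does whether hydroxy on another carbon of the ring would read the same.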